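Isomeric aryl swap on the sulfonamide nitrogen

A few compounds are considered here, and "the series" means these few. Any claim that something is new, unique, unknown or untested is made for them only; others in the source may bear on it.

Going by the values given here, the series so far comprises compound 1 `Cc1ccc(N(CC(C)C)S(=O)(=O)c2ccc3c(c2)C(=O)CC(C2CCOCC2)O3)c(C)c1`, compound 2 `CCc1ccc(N(CC(C)C)S(=O)(=O)c2ccc(OCC3CCOCC3)c3c2CCC3=O)cc1` and compound 3 `Cc1ccc(NS(=O)(=O)c2ccc3c(c2)C(=O)CC(C2CCOCC2)O3)c(C)c1`. In a physicochemical assay for lipophilicity, at pH 7.4 (a higher number here means a more lipophilic compound, a lower number a more polar compound), compound 1 gives 4.28, the second highest of the three numbers; compound 2 gives 4.44, within the scatter of compound 1, while compound 3 gives 2.75, the lowest. Among the compounds with values here, the only single-point step measured is a number 1.53 log units lower from compound 1 to compound 3 (beyond the scatter), and it concerns a different position. Compound 4 `CCc1ccc(N(CC(C)C)S(=O)(=O)c2ccc3c(c2)C(=O)CC(C2CCOCC2)O3)cc1` differs from compound 1 by 4-ethylphenyl in place of 2,4-dimethylphenyl on a sulfonamide nitrogen. Within the data shown here, no measured step bears on this change directly; since the two compounds share the same atoms, no step beyond the scatter is expected. Compound 4 is therefore estimated at 4.3, range 4 to 4.6, which means an expected step of a number 0.02 log units higher from compound 1 to compound 4 (within the scatter).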

Compound 4, distribution coefficient: 4.21
Beside the measured number, compound 4's estimate is 0.09 log units above it; the range from low to high includes it.
By their numbers in this assay, from the lowest: compound 3; then compounds 4, 1 and 2 (each within the scatter of the next).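

Moving the same eight carbons from 2,4-dimethylphenyl to 4-ethylphenyl on the sulfonamide nitrogen gives in this assay a number 0.07 log units lower from compound 1 to compound 4 (within the scatter) and is the first aryl change measured at this position. This step stays within the scatter, whereas a number 1.53 log units lower from compound 1 to compound 3 (beyond the scatter) records a large change for a different group on the same nitrogen. No available evidence accounts for the outcome.

Still open, on these data alone, is how this number responds when the aryl group on the nitrogen carries a carboxylic acid or an amine. As far as these compounds go, a pyridine ring in place of the phenyl ring is equally open.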